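The compounds below may be only part of what the source reports. "The series", "measured", "known", "first", "only" and "open" are said of these compounds alone.

Measured in an ADME assay on MT4 cells (Homo sapiens) for cytotoxicity; on this read-out higher numbers stand for lower toxicity in this test and lower numbers for higher toxicity in this test:

Compound 1 `CCNC(=S)Nc1cccc(C(F)(F)F)c1`: > 100000 nM (a limit)
Compound 2 `O=C(NC(=S)Nc1cccc(C(F)(F)F)c1)[C@H]1C[C@@H]2CC[C@H]1C2`: 42000 nM

Within the data shown here, compound 2 gives 42000 nM, the only true number so far. Compound 1 gives > 100000 nM, which is a limit of the assay and not a number. With so little data, compound 2 can only be placed against that limit.

The next compound is compound 3 `CC(=O)NC(=S)Nc1cccc(C(F)(F)F)c1`, not yet measured in this assay. The change from compound 2 is one carbon atom in place of a group of 7 heavy atoms (7 carbon; 2 five-membered non-aromatic rings of carbon only), on a carbonyl carbon. In plain terms, one carbon atom replaces a group of 7 heavy atoms, on a carbonyl carbon, and the rest of the molecule stays the same.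

Among the measured compounds shown here, no measured pair of compounds shows this exact change, so the expectation is tentative. For the measured compounds named here, compound 2, at 42000 nM, is the one measured compound with a number, and it carries the large group that compound 3 loses. A small step upward is expected, towards lower toxicity in this test, perhaps no larger than the usual scatter. The expected step is a 1.7-fold higher number from compound 2 to compound 3 (0.22 log units; within the scatter). For compound 3 the estimated value is 70000 nM, with an expected range from 30000 nM to 120000 nM.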

Compound 3, half-maximal cytotoxic concentration: > 100000 nM
Compound 3 ended at the assay's limit; the forecaster's own chance of this, stated with the estimate: 40%; middle value at least 1.4-fold (0.15 log units) from the limit.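

In this assay, replacing the group of 7 heavy atoms on the carbonyl carbon with methyl gives an at least 2.3-fold higher number from compound 2 to compound 3 (0.37 log units; beyond the scatter). Among these compounds, this is the first sign that the group at this place can move the read-out by more than the scatter, with the large group of two five-membered carbon rings going with the higher toxicity in this test. Compound 3 gives > 100000 nM, which is a limit of the assay and not a number, so compound 2 remains the only compound here with a true value, and the full size of the step stays unknown for this reason: the limit of > 100000 nM in this assay, at which 2 of the 3 values shown sit.

The step between the ethyl of compound 1 and the acetyl of compound 3 cannot be read, as both results are limits. Going by these compounds, it remains open how large the group on the carbonyl carbon must be before a true number appears again, for example with a longer chain such as butyl, a cyclohexyl ring or an amine at this place.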